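A Fluorine Moved: What to Expect for Compound 3

A few compounds are considered here, and "the series" means these few. Any claim that something is new, unique, unknown or untested is made for them only; others in the source may bear on it.

Compound 1 `O=C(C(Nc1ccccc1)c1ccc(C(F)(F)F)cc1)N1CCCC1c1ccccc1F`: 30 nM
Compound 2 `O=C(C(Nc1ccccc1F)c1ccc(C(F)(F)F)cc1)N1CCCC1c1ccccc1F`: 7 nM

Both were measured in an assay on HEK293 cells for antagonist activity at transient receptor potential M8 protein (Canis lupus familiaris), read by fluorescence and calcium flux, with a stated time of 5 min; on this read-out higher numbers stand for weaker inhibition and lower numbers for stronger inhibition. Among the compounds with values here, compound 2 stands at the lower of the two numbers; the only measured step, a 4.3-fold lower number from compound 1 to compound 2 (0.63 log units; beyond the scatter), came from fluoro in place of hydrogen on an aromatic carbon. Compound 3 `O=C(C(Nc1ccccc1F)c1ccc(C(F)(F)F)cc1)N1CCCC1c1cccc(F)c1` differs from compound 2 by 3-fluorophenyl in place of 2-fluorophenyl on a saturated ring carbon. Within the data shown here, no measured step bears on this change, which lies elsewhere than the one measured step. In this assay compound 3 is therefore expected near compound 2, with no step beyond the scatter: a 1.4-fold higher number from compound 2 to compound 3 (0.15 log units; within the scatter). Compound 3 is estimated at 10 nM, between 3 nM and 35 nM.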

Compound 3, half-maximal inhibitory concentration: 9 nM
Estimate against measurement, compound 3: 1.1-fold (0.05 log units) above; low and high end bracket the measured number.
By their numbers in this assay, from the lowest: compounds 2 and 3 (each within the scatter of the next); then compound 1.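

Putting 3-fluorophenyl in place of 2-fluorophenyl on the saturated ring carbon gives a 1.3-fold higher number from compound 2 to compound 3 (0.11 log units; within the scatter) in this assay. Within the data shown here, this is the first reading at this position, as the earlier step lay elsewhere in the molecule, and it shows that the two fluorine placements on this phenyl group cannot be told apart here. Nothing available explains this result. The compounds shown leave open whether any fluorine is needed on this phenyl group, and whether a chlorine or a methoxy group there would read alike.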